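Chain change from compound 2 to compound 3

The source may report more compounds than this note shows. Statements on the series, on what has been measured and on what is new or still open speak of the compounds shown alone.

- In a functional assay on K562 cells (Homo sapiens) for antiproliferative activity (on this read-out higher numbers stand for weaker inhibition and lower numbers for stronger inhibition), compound 1 `CCCCC(=O)N[C@@H]1[C@H]2OC(C)(C)O[C@H]2O[C@@H]1[C@H](O)CO` gives 5000000 nM
- In this assay compound 2 `CCCCCC(=O)N[C@@H]1[C@H]2OC(C)(C)O[C@H]2O[C@@H]1[C@H](O)CO` gives 10000000 nM

Among the measured compounds shown here, compound 2 stands within the scatter of compound 1, the only other measured compound. Compound 3 `CC(C)CC(=O)N[C@@H]1[C@H]2OC(C)(C)O[C@H]2O[C@@H]1[C@H](O)CO`, not yet measured, carries isopropyl in place of butyl on a saturated chain carbon bound to a carbonyl carbon on the same core. For the measured compounds named here, the only measured step bearing on this change is a 2.0-fold higher number from compound 1 to compound 2 (0.30 log units; within the scatter), so no step beyond the scatter is expected in this assay. The expected step is a 1.7-fold lower number from compound 2 to compound 3 (0.22 log units; within the scatter) and remains an estimate. For compound 3 the estimated value is 6000000 nM, with an expected range of 2500000 nM to 15000000 nM.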

Compound 3, half-maximal inhibitory concentration: 5000000 nM
Beside the measured number, compound 3's estimate is 1.2-fold (0.08 log units) above it, and the stated range covers the measured number.
By their numbers in this assay, from the lowest: compounds 1, 3 and 2 (each within the scatter of the next).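

In this assay, compound 3 is the only branched chain shown, and the branch on a saturated chain carbon bound to a carbonyl carbon stays within the scatter of both straight chains: isopropyl in place of butyl gives a 2.0-fold lower number from compound 2 to compound 3 (0.30 log units; within the scatter), and isopropyl in place of propyl gives no change at the digits printed from compound 1 to compound 3 (within the scatter). Among the compounds shown here, neither chain length nor this branch separates the three compounds so far. No evidence on hand explains this result. Still open, as far as these compounds go, is whether an amine, a carboxylic acid, a phenyl ring or a much longer chain at this place would give a step beyond the scatter.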